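The source may report more compounds than this note shows. Statements on the series, on what has been measured and on what is new or still open speak of the compounds shown alone.

Measured compounds:
- compound 2 `CNC(=O)c1cc(Oc2ccc(C(=O)/C=C/c3cc(OC)c(OC)c(OC)c3)cc2)ccn1` in a functional assay on A549 cells (Homo sapiens) for cytotoxicity, read by MTT assay, with a stated time of 72 h; on this read-out lower numbers stand for stronger inhibition and higher numbers for weaker inhibition: 9500 nM
- compound 3 `CNC(=O)c1cc(Oc2ccc(C(=O)/C=C/c3ccc(C#N)cc3)cc2)ccn1` in this assay: 26400 nM
- compound 1 `CNC(=O)c1cc(Oc2ccc(C(=O)/C=C/c3cccc([N+](=O)[O-])c3)cc2)ccn1` in this assay: "not determined" (no result reported)

Compound 1 therefore stands nowhere on the numbers shown: it has no value of its own, and all that is known comes from compound 2 and compound 3, which share its core and differ only in the group carried by the outer aromatic ring. Both of those give high numbers, that is, weak inhibition of cell growth.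

Compound 4 `CNC(=O)c1cc(Oc2ccc(C(=O)/C=C/c3ccccc3)cc2)ccn1` is compound 1 with one change: hydrogen in place of nitro on an aromatic carbon The nitro leaves and a hydrogen enters in its place, so the outer ring becomes a plain phenyl.

For the measured compounds named here, no direct step between measured compounds is available to set the size of this change in this assay. With no number for compound 1, no direction can be read from the data; the reasonable expectation is a value in the same weak range seen for compound 2 and compound 3, with no step beyond the scatter in either direction assumed. Compound 4 is therefore estimated at 15000 nM, expected to lie between 5000 nM and 50000 nM.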

Compound 4, half-maximal inhibitory concentration: 5040 nM
Beside the measured number, compound 4's estimate is 3.0-fold (0.47 log units) above it, and the stated range covers the measured number.
By their numbers in this assay, from the lowest: compounds 4 and 2 (each within the scatter of the next); then compound 3.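

Hydrogen in place of cyano on the outer ring gives a 5.2-fold lower number from compound 3 to compound 4 (0.72 log units; beyond the scatter) in this assay. This shows that the ring needs no cyano group to reach this level of cell-growth inhibition, and that a plain phenyl gives the better number of this pair. From the compounds shown here alone, the step from compound 1 to compound 4, the nitro-to-hydrogen change itself, cannot be read, as compound 1 has no value, so the effect of the nitro group on the number remains unknown. Nothing measured here gives a reason for the cyano step.

Still open, going by these compounds, is what an amine or a carboxylic acid on this ring would do to the number. Also open, on these data alone, is whether any group on this ring can give a lower number than the plain phenyl of compound 4.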